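Pyrrolidinyl ether enantiomer in the urotensin-2 series

The source may hold more compounds than are shown below. What is called first, only, known or untested is meant among the compounds shown, and "the series" means these compounds.

Measured so far:
compound 1 `CN(C)CCCOc1ccc(CN2CC[C@H](NC(=O)c3ccc(Cl)c(Cl)c3)C2)cc1Br` — 61 nM
compound 2 `O=C(N[C@H]1CCN(Cc2ccc(O[C@@H]3CCNC3)c(Br)c2)C1)c1ccc(Cl)c(Cl)c1` — 5.5 nM

Among the compounds with values here, in an assay on HEK293 cells for displacement of a labelled ligand from Urotensin-2 receptor (Homo sapiens) (on this read-out higher numbers stand for weaker inhibition and lower numbers for stronger inhibition), compound 2 gives the lowest number of the two; compound 1 gives 61 nM, with the only measured step being an 11-fold lower number from compound 1 to compound 2 (1.04 log units; beyond the scatter). Compound 3 `O=C(N[C@H]1CCN(Cc2ccc(O[C@H]3CCNC3)c(Br)c2)C1)c1ccc(Cl)c(Cl)c1` keeps every atom of compound 2: the two compounds have the same atoms and bonds and differ only in configuration as drawn: 1 of 2 stereo elements differ; a stereocentre at a saturated ring carbon is drawn R in compound 2 and S in compound 3. Within the data shown here, no measured step addresses a change of configuration, so that step offers no guide here, and nothing in the data points to a direction. The estimate for compound 3 is a modest, uncertain loss, a 2.7-fold higher number from compound 2 to compound 3 (0.44 log units; beyond the scatter), giving an expected 15 nM within 3 nM to 80 nM.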

Compound 3, inhibition constant: 44 nM
The estimate for compound 3 lay 2.9-fold (0.47 log units) below the measured number; low and high end bracket the measured number.
By their numbers in this assay, from the lowest: compound 2; then compounds 3 and 1 (each within the scatter of the next).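

In this assay the configuration of the saturated ring carbon in the pyrrolidin-3-yl ether matters, with R in compound 2 and S in compound 3: an 8.0-fold higher number from compound 2 to compound 3 (0.90 log units; beyond the scatter). Pyrrolidin-3-yl in place of 3-(dimethylamino)propyl brings a gain only with the R centre, as an 11-fold lower number from compound 1 to compound 2 (1.04 log units; beyond the scatter) stands against a 1.4-fold lower number from compound 1 to compound 3 (0.14 log units; within the scatter). The gap can be placed on this one centre because of a single fact: the fact that compounds 2 and 3 differ only in the configuration as drawn

From the compounds shown here alone, whether R remains favoured in a piperidin-3-yl or azetidin-3-yl ether stays open. So does the effect of a methyl group on the pyrrolidine nitrogen, and that of inverting the second stereocentre, which is drawn the same in all three compounds.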